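The source may report more compounds than this note shows. Statements on the series, on what has been measured and on what is new or still open speak of the compounds shown alone.

In an assay on SHEP1 cells for displacement of a labelled ligand from Neuronal acetylcholine receptor; alpha4/beta2 (Homo sapiens), read by scintillation counting, with a stated time of 2 h (a higher number here means a weaker inhibitor, a lower number a stronger inhibitor), compound 1 `O=C(c1ccco1)[C@H]1C[C@H]2CNC[C@H]2C1` gives 13 nM. Among the compounds with values here, compound 2 `COC(=O)[C@H]1C[C@H]2CNC[C@H]2C1` gives 8 nM in this assay; the one step measured so far, a 1.6-fold lower number from compound 1 to compound 2 (0.21 log units; within the scatter), is within the scatter, so compound 2 and compound 1 cannot be told apart on this assay, and compound 2 serves as the reference for the next step. Compound 3 `CNC(=O)[C@H]1C[C@H]2CNC[C@H]2C1` differs from compound 2 by methylamino in place of methoxy on a carbonyl carbon. Within the data shown here, no measured step exchanges an oxygen for a nitrogen at this place; the only step available, a 1.6-fold lower number from compound 1 to compound 2 (0.21 log units; within the scatter), touches the same carbonyl carbon and stayed within the scatter, which is the sole guide here. The exchange is therefore expected to give only a small step, a 1.9-fold higher number from compound 2 to compound 3 (0.27 log units; within the scatter), with the direction left open. Compound 3 is estimated at 15 nM in this assay, with a range from 5 nM to 50 nM.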

Compound 3, inhibition constant: 180 nM
Compound 3: middle estimate off by 12-fold (1.08 log units), on the low side, and the stated range ends below it.
By their numbers in this assay, from the lowest: compounds 2 and 1 (each within the scatter of the next); then compound 3.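

At this carbonyl carbon the group is not interchangeable: in this assay methylamino in place of methoxy gives a 23-fold higher number from compound 2 to compound 3 (1.35 log units; beyond the scatter), whereas the earlier exchange of furan-2-yl for methoxy stayed within the scatter. Measured against the furan-2-yl ketone, the result is similar, with a 14-fold higher number from compound 1 to compound 3 (1.14 log units; beyond the scatter), so methylcarbamoyl separates compound 3 from both compound 1 and compound 2, which themselves cannot be told apart. No available measurement accounts for the size of this step.
On these data alone, it remains open whether the step follows the amide hydrogen or the nitrogen as such, and a dimethylamino group on the same carbonyl carbon would separate the two. An unsubstituted amino group or a longer chain on the nitrogen, such as ethylamino, would show whether the methylamino value is typical of amides here.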